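Series notes: imine in place of amide on the shared core

A few compounds are considered here, and "the series" means these few. Any claim that something is new, unique, unknown or untested is made for them only; others in the source may bear on it.

Measured compounds in a functional assay on Ehrlich cells (Mus musculus) for cytotoxicity, read by trypan blue exclusion, with a stated time of 2 h, tested at 10 ug/mL; a lower number here means a weaker effect, a higher number a stronger effect of the compound at the concentration tested:
- compound 1, `CC(Cl)CC(=O)NC1=C(C#N)C(c2ccc(Cl)cc2Cl)C2=C(CCCC2=O)N1c1ccc(S(N)(=O)=O)cc1`, gives 20%
- compound 2, `N#CC1=C(NC(=O)/C=C/c2ccccc2)N(c2ccc(S(N)(=O)=O)cc2)C2=C(C(=O)CCC2)C1c1ccc(Cl)cc1Cl`, gives 30%

Among the compounds with values here, compound 2 stands alongside compound 1; the only recorded step, a number 10 percentage points higher from compound 1 to compound 2 (within the scatter), does not separate the two. Compound 3, `CN(C)c1ccc(/C=N/C2=C(C#N)C(c3ccc(Cl)cc3Cl)C3=C(CCCC3=O)N2c2ccc(S(N)(=O)=O)cc2)cc1`, is not yet measured. Its change from compound 2 is a group of 11 heavy atoms (9 carbon, 2 nitrogen; one six-membered aromatic ring of carbon only) in place of a group of 11 heavy atoms (9 carbon, 1 nitrogen, 1 oxygen; one six-membered aromatic ring of carbon only), on a double-bonded ring carbon. Within the data shown here, no measured step touches this part of the core, so the single recorded step gives no direction, and nothing beyond the scatter is expected in this assay. Compound 3 is expected to give 25%, estimated between 10% and 40%, meaning an expected step of a number 5 percentage points lower from compound 2 to compound 3 (within the scatter).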

Compound 3, a percentage reported as activity, at one concentration (the size of the read-out at that concentration, not a potency): 10%
Beside the measured number, compound 3's estimate is 15 percentage points above it; measured number inside the range.
By their numbers in this assay, from the lowest: compounds 3, 1 and 2 (each within the scatter of the next, the first and the last beyond it).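

In this assay, within the data shown here, the imine at this double-bonded ring carbon gives a number 20 percentage points lower from compound 2 to compound 3 (beyond the scatter), the first step beyond the scatter, whereas a number 10 percentage points lower from compound 1 to compound 3 (within the scatter) stays within it. The position therefore responds to this change only against the 2-phenylethenyl amide, and the imine is not separated from the 2-chloropropyl amide. Nothing measured here accounts for the difference.

The compounds shown do not separate the imine link from the dimethylamino group on its aromatic ring. An imine with a plain phenyl, a methoxy or a hydroxy group there would test that.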